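A few compounds are considered here, and "the series" means these few. Any claim that something is new, unique, unknown or untested is made for them only; others in the source may bear on it.

In a functional assay on A549 cells (Homo sapiens) for antiproliferative activity, read by sulforhodamine B assay, with a stated time of 3 days (on this read-out lower numbers stand for stronger inhibition of growth and higher numbers for weaker inhibition of growth), three compounds sharing one core have been measured. Compound 1 `O=C(NCCO)c1cccc(Nc2ncc(F)c(Nc3ccc(F)cc3)n2)c1` gives 11900 nM, compound 2 `O=C(Nc1cc(Cl)cc(Cl)c1)c1cccc(Nc2ncc(F)c(Nc3ccc(F)cc3)n2)c1` gives 17500 nM, and compound 3 `O=C(Nc1cccc(Nc2ncc(F)c(Nc3ccc(F)cc3)n2)c1)c1ccccc1` gives 37800 nM, the highest of the three numbers. Its gap to the nearest number is a 2.2-fold higher number from compound 2 to compound 3 (0.33 log units; beyond the scatter), and to the furthest a 3.2-fold higher number from compound 1 to compound 3 (0.50 log units; beyond the scatter); both are modest but beyond the scatter. Compound 4 `O=C(Nc1cccc(Nc2ncc(F)c(Nc3ccc(F)cc3)n2)c1)c1cccc([N+](=O)[O-])c1` differs from compound 3 by nitro in place of hydrogen on an aromatic carbon. Within the data shown here, none of the measured steps bears directly on this change: the step of a 1.5-fold higher number from compound 1 to compound 2 (0.17 log units; within the scatter) exchanges the group on the amide nitrogen, and the two steps ending at compound 3 reverse the amide itself. The three measured numbers lie within a narrow band, and nothing shown indicates that a substituent on the outer phenyl shifts the number strongly. The step from compound 3 is therefore expected to be a 1.1-fold lower number from compound 3 to compound 4 (0.03 log units; within the scatter), not beyond the scatter. Compound 4 is accordingly estimated at 35000 nM, with a range from 14000 nM to 90000 nM.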

Compound 4, concentration for 50% growth inhibition: 7250 nM
Compound 4: the middle estimate sits 4.8-fold (0.68 log units) above what was measured, and the stated range ends above it.
By their numbers in this assay, from the lowest: compounds 4, 1 and 2 (each within the scatter of the next, the first and the last beyond it); then compound 3.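

In this assay, replacing benzoyl by (3-nitrophenyl)carbonyl gives a 5.2-fold lower number from compound 3 to compound 4 (0.72 log units; beyond the scatter) in this series, so this aromatic carbon, meta to a large group, is a place where one added group moves the number beyond the scatter. The earlier compounds shown here had changed only the amide, its direction and the group on its nitrogen, and so gave no reading of a substituent on this ring. Nothing given here bears on why the number falls.

The compounds shown leave open whether the drop belongs to nitro itself or would also come with an amine or a carboxylic acid on the same carbon. They also leave open whether nitro on another carbon of this ring would give a step of similar size.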